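This account rests on a few compounds, and the source may have more. Where it says the series, first, only, none or still open, it means among the compounds named here.

Measured so far:
- compound 1, `CN1CCN(c2cc(CN3C(=O)N(c4ccc(SC(F)(F)F)cc4)C(=O)C3(C)C)ccn2)CC1`: 0.159 ug/mL
- compound 2, `CC1(C)C(=O)N(c2ccc(SC(F)(F)F)cc2)C(=O)N1Cc1ccnc(C(=O)O)c1`: 0.142 ug/mL
- compound 3, `CC1(C)C(=O)N(c2ccc(SC(F)(F)F)cc2)C(=O)N1Cc1ccnc(Nc2ccccc2)c1`: < 0.025 ug/mL

In a physicochemical assay for solubility, read by nephelometry (on this read-out lower numbers stand for lower solubility and higher numbers for higher solubility), compound 1 gives 0.159 ug/mL, the highest of the two numbers that are not limits. Compound 2, with a carboxy group in place of the 4-methylpiperazin-1-yl group, sits very close: a 1.1-fold lower number from compound 1 to compound 2 (0.05 log units; within the scatter). For compound 3 the assay reports only a limit, < 0.025 ug/mL, so its solubility is not known as a number (the limit of < 0.025 ug/mL in this assay, at which 1 of the 3 values shown sits). Even so, the step is clear: an at least 6.3-fold lower number from compound 1 to compound 3 (0.80 log units; beyond the scatter), and likewise an at least 5.6-fold lower number from compound 2 to compound 3 (0.75 log units; beyond the scatter).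

Compound 4, `CC1(C)C(=O)N(c2ccc(SC(F)(F)F)cc2)C(=O)N1Cc1ccnc(NCc2ccccc2)c1`, has not yet been measured. It differs from compound 1 in one place: benzylamino in place of 4-methylpiperazin-1-yl on an aromatic carbon. The entering group carries a six-membered aromatic ring of carbon only, as does the anilino group of compound 3, so the step of an at least 6.3-fold lower number from compound 1 to compound 3 (0.80 log units; beyond the scatter) is the closest guide. A drop of at least modest size is therefore expected, a 5.3-fold lower number from compound 1 to compound 4 (0.72 log units; beyond the scatter). Compound 4 is estimated at 0.03 ug/mL, with a range from 0.01 ug/mL to 0.1 ug/mL.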

Compound 4, solubility: < 0.026 ug/mL
Compound 4 was reported as a limit; the forecaster's own chance of this, stated with the estimate: 55%; at least 1.1-fold (0.06 log units) between middle value and limit.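

With benzylamino on this aromatic carbon next to the ring nitrogen, the number again drops in this assay: an at least 6.1-fold lower number from compound 1 to compound 4 (0.78 log units; beyond the scatter), and an at least 5.4-fold lower number from compound 2 to compound 4 (0.73 log units; beyond the scatter). The drop is therefore not tied to the anilino group alone: among these four compounds, the two whose entering group carries a six-membered aromatic ring of carbon only are the two reported as limits, and no compound shown goes against this. The step from phenyl to benzyl on the nitrogen cannot be read, as both of its ends are limits.

Still open, on these data alone, is whether the drop goes with the aromatic ring itself or with any carbon ring at this position. A cyclohexylmethylamino group, or a pyridylmethylamino group with a nitrogen in the ring, would help to separate these possibilities.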